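This account rests on a few compounds, and the source may have more. Where it says the series, first, only, none or still open, it means among the compounds named here.

In a physicochemical assay for solubility, read by nephelometry, measured as kinetic solubility, at pH 2 (on this read-out lower numbers stand for lower solubility and higher numbers for higher solubility), compound 1 (`O=C(NNS(=O)(=O)c1ccccc1F)c1cc(F)cc(-n2cccn2)c1`) gives 25 ug/mL while compound 2 (`C=CCOc1ccc(F)c(C(=O)NNS(=O)(=O)c2ccccc2)c1`) gives 50 ug/mL and compound 3 (`Cc1cc(-c2ncccn2)cc(C(=O)NNS(=O)(=O)c2ccccc2)c1F`) gives 50 ug/mL as well, so compound 3 stands level with compound 2 and within the scatter of compound 1. Compound 4 (`Cc1cc(-c2ccccn2)cc(C(=O)NNS(=O)(=O)c2ccccc2)c1F`), not yet measured, carries pyridin-2-yl in place of pyrimidin-2-yl on an aromatic carbon, para to a fluoro group and meta to a methyl group (pyridin-2-yl in place of pyrimidin-2-yl on an aromatic carbon). No measured pair of these compounds differs in one place, so the data give no direct guide to this change. In this assay no change beyond the scatter is expected, and the estimated step is small (a 1.3-fold lower number from compound 3 to compound 4 (0.10 log units; within the scatter)). Compound 4 is expected at 40 ug/mL with an estimated range from 18 ug/mL to 90 ug/mL in all.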

Compound 4, solubility: 50 ug/mL
The estimate for compound 4 lay 1.3-fold (0.10 log units) below the measured number; the range from low to high includes it.
By their numbers in this assay, from the lowest: compounds 1, 2, 3 and 4 (each within the scatter of the next).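

In this assay, pyridin-2-yl in place of pyrimidin-2-yl on an aromatic carbon, para to a fluoro group and meta to a methyl group, gives no change at the digits printed from compound 3 to compound 4 (within the scatter). For the compounds shown here, this is the only step here between compounds that differ in one place, and it shows that this exchange of one ring nitrogen for carbon leaves the read-out unmoved at this position. Nothing measured here offers a reason for this result.

The compounds shown leave open whether a group of another kind at this position, such as an amine or a carboxylic acid, would move the number beyond the scatter.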